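The source may hold more compounds than are shown below. What is called first, only, known or untested is meant among the compounds shown, and "the series" means these compounds.

In an ADME assay on HEK293-A cells (Homo sapiens) for cytotoxicity, read by MTT assay, with a stated time of 48 h (a higher number here means a weaker inhibitor, a lower number a stronger inhibitor), compound 1 `O=C1CNC(=O)N1C[C@H]1CN(c2ccc(-n3cc(-c4ccccn4)cn3)c(F)c2)C(=O)O1` gives only a limit, > 400 ug/mL. Compound 2 `COC[C@H]1CN(c2ccc(-n3cc(-c4ccccn4)cn3)c(F)c2)C(=O)O1` likewise reaches only the limit > 400 ug/mL. For the measured compounds named here, compound 3 `CCNC(=O)NC[C@H]1CN(c2ccc(-n3cc(-c4ccccn4)cn3)c(F)c2)C(=O)O1` is the sole member with an actual number, giving 29 ug/mL. The other two rest at the limit of > 400 ug/mL in this assay, at which 2 of the 3 values shown sit. Both an at least 13-fold lower number from compound 1 to compound 3 (1.13 log units; beyond the scatter) and an at least 13-fold lower number from compound 2 to compound 3 (1.13 log units; beyond the scatter) were large drops, each exchanging a group on a saturated chain carbon bound to a saturated ring carbon. Going by the values given here, compound 4 `O=C(NC[C@H]1CN(c2ccc(-n3cc(-c4ccccn4)cn3)c(F)c2)C(=O)O1)C(F)F` differs from compound 3 by difluoromethyl in place of ethylamino on a carbonyl carbon, a change on a carbonyl carbon that no measured step has touched. Lacking a comparable step, a moderate rise back toward the limit is expected, a 3.4-fold higher number from compound 3 to compound 4 (0.54 log units; beyond the scatter). Compound 4 is therefore estimated at 100 ug/mL, somewhere between 25 ug/mL and 400 ug/mL.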

Compound 4, half-maximal inhibitory concentration: 167 ug/mL
Compound 4: the middle estimate sits 1.7-fold (0.22 log units) below what was measured, within the range that was stated.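

For the compounds shown here, changing only what sits on the carbonyl carbon, with difluoromethyl in place of ethylamino, gives a 5.8-fold higher number from compound 3 to compound 4 (0.76 log units; beyond the scatter) in this assay and shows that the number responds at a carbonyl carbon, a place no earlier step had touched. The ((difluoromethyl)carbonyl)amino group still lands in the middle of the series, with an at least 2.3-fold lower number from compound 2 to compound 4 (0.37 log units; beyond the scatter) and an at least 2.3-fold lower number from compound 1 to compound 4 (0.37 log units; beyond the scatter) as its other two steps. Those two comparisons rest on limits: the limit of > 400 ug/mL in this assay, at which 2 of the 4 values shown sit. Open, going by these compounds, is how a methyl or a trifluoromethyl on the same carbonyl carbon would read, which would separate the loss of ethylamino from the gain of fluorine.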